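A smaller group on the carbonyl carbon

The source may report more compounds than this note shows. Statements on the series, on what has been measured and on what is new or still open speak of the compounds shown alone.

Measured so far in an ADME assay on MDCKII-LE cells (Canis lupus familiaris) for permeability; on this read-out lower numbers stand for lower permeability and higher numbers for higher permeability:
- compound 1 `Cc1cc2c(Oc3cnc(C(=O)N4CC(C)(C)C4)cn3)cc(C(=O)Nc3cnccn3)cc2o1`: 7.7 10^-6 cm/s
- compound 2 `Cc1cc2c(Oc3cnc(C(=O)N4CC5(COC5)C4)cn3)cc(C(=O)Nc3cnccn3)cc2o1`: 19.9 10^-6 cm/s

Of these two, compound 2 stands higher, at 19.9 10^-6 cm/s. Compound 3 `Cc1cc2c(Oc3cnc(C(=O)N(C)C)cn3)cc(C(=O)Nc3cnccn3)cc2o1` has not been measured yet. It keeps the core of compound 2 and changes one group: a group of 3 heavy atoms (2 carbon, 1 nitrogen; no ring) in place of a group of 7 heavy atoms (5 carbon, 1 nitrogen, 1 oxygen; 2 four-membered non-aromatic rings with 1 hetero atom each), on a carbonyl carbon.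

Among the measured compounds shown here, only one measured step bears on this change. Compounds 1 and 2 also differ at that carbonyl carbon, and the step is a 2.6-fold higher number from compound 1 to compound 2 (0.41 log units; beyond the scatter), modest but beyond the usual scatter. A single step is thin evidence, and dimethylamino appears in neither measured compound, so even the direction is uncertain. Compound 2 holds the higher of the two values, so a fall is the more likely outcome, and it is expected to be smaller than that measured step. The expected step in this assay is a 1.7-fold lower number from compound 2 to compound 3 (0.22 log units; within the scatter), and it may stay within the scatter. For compound 3 the estimated value is 12 10^-6 cm/s, with an expected range of 6 10^-6 cm/s to 24 10^-6 cm/s.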

Compound 3, apparent permeability: 30 10^-6 cm/s
Compound 3: middle estimate off by 2.5-fold (0.40 log units), on the low side; measured number above the stated range.
By their numbers in this assay, from the lowest: compound 1; then compounds 2 and 3 (each within the scatter of the next).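

In this assay, the replacement of the two-ring group by dimethylamino gives a 1.5-fold higher number from compound 2 to compound 3 (0.18 log units; within the scatter), so the much smaller group on this carbonyl carbon gives a number that cannot be told apart from that of the larger group. Dimethylamino in place of 3,3-dimethylazetidin-1-yl gives a 3.9-fold higher number from compound 1 to compound 3 (0.59 log units; beyond the scatter), which means that the number of heavy atoms in the group does not by itself order these values: the group with the fewest atoms and the group with the most sit together, while 3,3-dimethylazetidin-1-yl, with a count between them, gives the lowest number. Nothing measured here explains why these groups separate in this way.

From the compounds shown here alone, it remains open whether methylamino, which would keep an amide hydrogen, or a six-membered ring such as morpholin-4-yl would stay close to compound 2 and compound 3 or drop towards compound 1. Going by these compounds, all three compounds also share the same core, so it is unknown whether this order of groups would hold on a different one.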